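Ester tail variation on the amine nitrogen of the core

The source may report more compounds than this note shows. Statements on the series, on what has been measured and on what is new or still open speak of the compounds shown alone.

Compound 1 `CCOC(=O)CNC(=O)NC1=CS(=O)(=O)O[C@@]12[C@@H](CO[Si](C)(C)C(C)(C)C)O[C@@H](n1cc(C)c(=O)n(C)c1=O)[C@@H]2O[Si](C)(C)C(C)(C)C` gives 13000 nM in a functional assay on HEL cells (Homo sapiens) (a higher number here means that more compound is tolerated, a lower number that less compound is tolerated), and compound 2 `COC(=O)CCNC1=CS(=O)(=O)O[C@@]12[C@@H](CO[Si](C)(C)C(C)(C)C)O[C@@H](n1cc(C)c(=O)n(C)c1=O)[C@@H]2O[Si](C)(C)C(C)(C)C` gives 94000 nM in this assay, the highest of the two numbers. Going by the values given here, the one measured step, a 7.2-fold higher number from compound 1 to compound 2 (0.86 log units; beyond the scatter), exchanges the whole substituent on the amine nitrogen. Compound 3 `Cc1cn([C@@H]2O[C@H](CO[Si](C)(C)C(C)(C)C)[C@@]3(OS(=O)(=O)C=C3NCC(=O)OCc3ccccc3)[C@H]2O[Si](C)(C)C(C)(C)C)c(=O)n(C)c1=O` carries benzyloxycarbonyl in place of (methoxycarbonyl)methyl on a saturated chain carbon bound to an amine nitrogen. Among the compounds with values here, no measured step changes only the ester end of this chain, so the step from compound 2 is expected to stay within the scatter, a 1.6-fold lower number from compound 2 to compound 3 (0.19 log units; within the scatter). Compound 3 is estimated at 60000 nM in this assay, with a range from 15000 nM to 200000 nM.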

Compound 3, half-maximal cytotoxic concentration: > 200000 nM
Compound 3 gave a limit, no number; the forecaster's own chance of this, stated with the estimate: 15%; middle value at least 3.3-fold (0.52 log units) from the limit.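

Compound 3 reads only as a limit in this assay: the limit of > 200000 nM in this assay, at which 1 of the 3 values shown sits.

Benzyloxycarbonyl in place of (methoxycarbonyl)methyl on a saturated chain carbon bound to an amine nitrogen gives an at least 2.1-fold higher number from compound 2 to compound 3 (0.32 log units; beyond the scatter), so a change confined to the far end of this chain already moves the read-out beyond the scatter. Against ((ethoxycarbonyl)methyl)carbamoyl on an amine nitrogen, (benzyloxycarbonyl)methyl gives an at least 15-fold higher number from compound 1 to compound 3 (1.18 log units; beyond the scatter).

From the compounds shown here alone, the full size of both steps stays open at this limit. Also open, going by these compounds, is whether a free carboxylic acid at the chain end would follow the esters.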